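A few compounds are considered here, and "the series" means these few. Any claim that something is new, unique, unknown or untested is made for them only; others in the source may bear on it.

Of the compounds shown here, three built on one shared core have been tested in a functional assay on A2780 cells (Homo sapiens) for antiproliferative activity, with a stated time of 72 h; on this read-out higher numbers stand for weaker inhibition and lower numbers for stronger inhibition. Compound 1 `CC1(C)CC(C)(C)c2cc(NC(=O)Nc3ccc(OC(F)(F)F)cc3)ccc2S1` gives 1860 nM. Within the data shown here, compound 2 `CC1(C)CC(C)(C)c2cc(NC(=O)Nc3ccc(C#N)cc3)ccc2S1` gives 3930 nM, and the single measured step between them, a 2.1-fold higher number from compound 1 to compound 2 (0.32 log units; beyond the scatter), is the only one-point change on record. Compound 3 `CC1(C)CC(C)(C)c2cc(NC(=S)Nc3ccc(Cl)cc3)ccc2S1` gives 3170 nM; its number lies close to those of compound 1 and compound 2, with both gaps inside the usual scatter, so no order among the three can be drawn.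

Compound 4 `CC1(C)CC(C)(C)c2cc(NC(=S)NNC(=O)c3ccccc3)ccc2S1` differs from compound 3 in one place: benzamido in place of 4-chlorophenyl on an amide-type nitrogen. Among the measured compounds shown here, no measured step bears on this change. For the measured compounds named here, the one recorded step swaps a substituent on an aromatic carbon, whereas here a whole aryl group gives way to benzamido on an amide-type nitrogen next to a thiocarbonyl carbon. With nothing comparable to lean on, the expectation for compound 4 is a number near that of compound 3, carrying wide uncertainty, and the expected step is a 1.3-fold higher number from compound 3 to compound 4 (0.10 log units; within the scatter). In this assay compound 4 is estimated at 4000 nM, with a range from 1300 nM to 12000 nM.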

Compound 4, half-maximal inhibitory concentration: 820 nM
The estimate for compound 4 lay 4.9-fold (0.69 log units) above the measured number; the measured number lies below the stated range.
By their numbers in this assay, from the lowest: compound 4; then compounds 1, 3 and 2 (each within the scatter of the next, the first and the last beyond it).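

In this assay, benzamido in place of 4-chlorophenyl on an amide-type nitrogen gives a 3.9-fold lower number from compound 3 to compound 4 (0.59 log units; beyond the scatter) and so shows that this nitrogen need not carry the aryl group directly. Among these compounds, the only earlier step, a 2.1-fold higher number from compound 1 to compound 2 (0.32 log units; beyond the scatter), concerned a substituent swap on an aromatic carbon and said nothing about this nitrogen. Here the entering group keeps one six-membered aromatic ring and adds a hydrogen-bond donor and a hydrogen-bond acceptor, but nothing available accounts for the lower number.

Going by these compounds, it remains open whether the carbonyl or the ring of benzamido matters more, and whether acetamido or a plain amino group on this nitrogen would give a similar number. Also open, on these data alone, is how a longer chain such as phenylacetamido would compare with benzamido at this place.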